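The source may hold more compounds than are shown below. What is called first, only, known or untested is meant among the compounds shown, and "the series" means these compounds.

Measured in a functional assay on MIA PaCa-2 cells (Homo sapiens) for inhibition, read by MTT assay, with a stated time of 3 days; on this read-out higher numbers stand for weaker inhibition and lower numbers for stronger inhibition:
- compound 1 `CCN(CC)S(=O)(=O)c1ccc(S(=O)(=O)N2CCC[C@@H](C(=O)N[C@H]3CC[C@H](OC)CC3)C2)cc1` gives 2290 nM
- compound 2 `O=C([C@@H]1CCCN(S(=O)(=O)c2ccc(S(=O)(=O)N3CC[C@@H](O)C3)cc2)C1)N1CCC(F)(F)CC1` gives 135 nM
- compound 3 `CCN(CC)S(=O)(=O)c1ccc(S(=O)(=O)N2CCC[C@@H](C(=O)N3CCC(O)CC3)C2)cc1` gives 230 nM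

Compound 2 and compound 3 lie within the scatter of each other, and both stand well under compound 1. Compound 4 `CC(C)S(=O)(=O)c1ccc(S(=O)(=O)N2CCC[C@@H](C(=O)N3CCC(F)(F)CC3)C2)cc1` departs from compound 2 by isopropyl in place of 3-hydroxypyrrolidin-1-yl on a sulfonyl sulfur. For the measured compounds named here, the only measured step, a 10-fold lower number from compound 1 to compound 3 (1.00 log units; beyond the scatter), concerns a group on a carbonyl carbon, so it gives no size for a change on the sulfonyl sulfur. Compound 3 differs from compound 2 on that sulfur and on the carbonyl carbon, yet compound 3 stays close at 230 nM. No step beyond the scatter is therefore expected in this assay, only a loose expectation. The expected step is a 1.5-fold higher number from compound 2 to compound 4 (0.17 log units; within the scatter). For compound 4 the estimated value is 200 nM, with an expected range from 70 nM to 700 nM.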

Compound 4, half-maximal inhibitory concentration: 9.1 nM
For compound 4 the middle estimate is 22-fold (1.34 log units) above the measured one, and the stated range ends above it.
By their numbers in this assay, from the lowest: compound 4; then compounds 2 and 3 (each within the scatter of the next); then compound 1.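

In this assay the group on the sulfonyl sulfur turns out to matter strongly: isopropyl in place of 3-hydroxypyrrolidin-1-yl gives a 15-fold lower number from compound 2 to compound 4 (1.17 log units; beyond the scatter), the first size shown for a change at this place. The earlier step concerned only a group on a carbonyl carbon. Nothing given here accounts for this step. Still open, as far as these compounds go, is whether the step belongs to isopropyl itself or to the loss of the ring and its hydroxyl. A cyclopropyl, a tert-butyl or an unsubstituted pyrrolidin-1-yl on that sulfur would help to separate these.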